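The source may hold more compounds than are shown below. What is called first, only, known or untested is meant among the compounds shown, and "the series" means these compounds.

Working notes on the series. Compound 1 `Cc1nn(-c2ncnc3nc[nH]c23)c2c1C(c1ccc(F)cc1Cl)CC(=O)N2` is examined in a functional assay on HEK293 cells for agonist activity at G-protein coupled receptor 39 (Homo sapiens), read by scintillation proximity assay and inositol phosphate accumulation, with a stated time of 75 min, in the presence of a further agent that is not named here (a lower number here means that less compound is needed, a higher number that more compound is needed for the effect), where compound 1 gives 9 nM. For the measured compounds named here, this is the lowest of the two numbers so far; the nearest is compound 2 `CC(C)(C)c1cc(C(=O)N/N=C/c2ccc(O)cc2O)[nH]n1`, which in this assay gives 240 nM, a gap beyond the usual scatter. Going by the values given here, no step between two measured compounds that differ in one place is available, so the change to compound 3 `Cc1nn(-c2ncnc3nc[nH]c23)c2c1C(NC(=O)c1ccccc1)CC(=O)N2` rests on the structures alone. The difference from compound 1 is benzamido in place of 2-chloro-4-fluorophenyl on a saturated ring carbon. Compound 3 exchanges an aromatic ring bound directly to the saturated ring carbon for a group attached through an amide, which is expected to cost activity, so the step from compound 1 is estimated as a 33-fold higher number from compound 1 to compound 3 (1.52 log units; beyond the scatter). Compound 3 is thus expected to give about 300 nM in this assay, with a range from 50 nM to 3000 nM.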

Compound 3, half-maximal effective concentration: 3 nM
The estimate for compound 3 lay 100-fold (2.00 log units) above the measured number; measured number outside the range, below it.
By their numbers in this assay, from the lowest: compound 3; then compound 1; then compound 2.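

On the saturated ring carbon of the shared core, benzamido in place of 2-chloro-4-fluorophenyl gives a 3.0-fold lower number from compound 1 to compound 3 (0.48 log units; beyond the scatter) in this assay. This position therefore accepts a benzene ring attached through an amide as well as one bound directly to the ring carbon, and the number still falls when chlorine and fluorine leave and an amide enters. Nothing available bears on the reason for this step.

The compounds shown leave open whether the amide link or the aromatic ring of benzamido matters more, and whether an acetamido group or a free amine on the same carbon would hold the number. Going by these compounds, it also remains open how chlorine or fluorine on the ring of benzamido would change the result.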